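Replacing the Amide Side Group of Compound 1

The source may hold more compounds than are shown below. What is called first, only, known or untested is meant among the compounds shown, and "the series" means these compounds.

Compound 1 `Cc1nc(NC(=O)C(C)(C)CC(F)(F)F)sc1-c1ccc(N)nc1` has been tested in a physicochemical assay for solubility, at pH 2; on this read-out higher numbers stand for higher solubility and lower numbers for lower solubility. In this measurement compound 1 gives > 1000 ug/mL, which is a limit of the assay and not an exact number. Compound 2 `Cc1nc(NC(=O)CN2C(=O)OC[C@H]2C(C)C)sc1-c1ccc(N)cc1` gives > 814 ug/mL, and this too is only a limit. As far as these compounds go, the true solubility of compound 1 therefore remains unknown, and the two compounds cannot be ranked.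

Compound 3 `CO[C@H]1CC[C@@H](C(=O)Nc2nc(C)c(-c3ccc(N)nc3)s2)CC1` keeps the core of compound 1 and changes one group, on a carbonyl carbon: 4-methoxycyclohexyl in place of 3,3,3-trifluoro-1,1-dimethylpropyl on a carbonyl carbon. Within the data shown here, no two measured compounds differ in just one place, so no measured step shows how large such a change tends to be. In this assay, the expectation is a modest downward step, or none beyond the usual scatter. The estimated change is an at least 1.4-fold lower number from compound 1 to compound 3 (0.15 log units; that floor lies within the scatter), and it remains uncertain. This expectation rests on the limit reached by compound 1, > 1000 ug/mL, and on the structural change alone. Compound 3 is expected to read about 700 ug/mL, with an estimated range of 250 ug/mL to 1500 ug/mL.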

Compound 3, solubility: > 1000 ug/mL
Compound 3 was reported as a limit; the forecaster's own chance of this, stated with the estimate: 55%; middle value at least 1.4-fold (0.15 log units) from the limit.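

In this assay compound 3 gives > 1000 ug/mL, which is a limit of the assay and not an exact number. No step can be read from compound 1 to compound 3 because both compounds sit at the same limit: the limit of > 1000 ug/mL in this assay, at which 2 of the 3 values shown sit.

The compounds shown leave open how far each true value lies beyond its limit, and whether 4-methoxycyclohexyl or 3,3,3-trifluoro-1,1-dimethylpropyl gives the higher reading.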